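Removing a Methyl from the Anisole of Compound 2

The compounds below may be only part of what the source reports. "The series", "measured", "known", "first", "only" and "open" are said of these compounds alone.

Three compounds share one core, and their growth inhibition was followed in a functional assay on SK-OV-3 cells (Homo sapiens) for inhibition, read by sulforhodamine B assay, with a stated time of 48 h; a higher number here means a weaker inhibitor of growth, a lower number a stronger inhibitor of growth. Compound 1 `COc1cc(-c2nn(-c3cccc(NC(=O)c4ccc(Cl)c(C(F)(F)F)c4)c3)cc2-c2ccncc2)ccc1Cl` reached only the limit of the assay, giving > 32500 nM. Compound 3 `COc1cc(-c2nn(-c3cccc(NC(=O)c4ccccc4)c3)cc2-c2ccncc2)ccc1Cl` likewise gave only a limit, > 100000 nM. Going by the values given here, compound 2 `COc1cc(-c2nn(-c3cccc(NC(=O)Nc4ccc(Cl)c(C(F)(F)F)c4)c3)cc2-c2ccncc2)ccc1Cl` is the only one with a number: in this assay compound 2 gives 13000 nM, so it stands as the sole measured point. The steps among these three concern the group on the carbonyl carbon: an at least 2.5-fold lower number from compound 1 to compound 2 (0.39 log units; beyond the scatter), an at least 7.6-fold higher number from compound 2 to compound 3 (0.88 log units; beyond the scatter), while a step that the two limits leave unreadable from compound 1 to compound 3.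

Compound 4 `O=C(Nc1cccc(-n2cc(-c3ccncc3)c(-c3ccc(Cl)c(O)c3)n2)c1)Nc1ccc(Cl)c(C(F)(F)F)c1` changes a different part of the molecule: hydrogen in place of methyl on an oxygen on an aromatic ring. Among the compounds with values here, none of the measured steps touch this oxygen, so no step bears directly on it, and the change is small in size. Compound 4 is therefore expected to stay close to compound 2, with no change at the digits printed from compound 2 to compound 4 (within the scatter) as the estimated step, no step beyond the scatter. For compound 4 the estimate in this assay is 13000 nM, within a range from 4000 nM to 40000 nM.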

Compound 4, concentration for total growth inhibition: 14900 nM
Beside the measured number, compound 4's estimate is 1.1-fold (0.06 log units) below it; the measured number falls inside the stated range.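

Replacing methoxy with hydroxy on the 4-chloro-3-methoxyphenyl group gives a 1.1-fold higher number from compound 2 to compound 4 (0.06 log units; within the scatter). Going by these compounds alone, this is the first reading at this oxygen, since the earlier steps all concerned the group on the carbonyl carbon, and it shows that in this pair the methyl can be exchanged for hydrogen without separating the two compounds in this assay. The data shown offer no measurement that would explain this result.

As far as these compounds go, it remains open whether this position would accept something larger on the oxygen, such as an ethyl group or a longer chain, or an amine in place of the hydroxy. From the compounds shown here alone, it is also open whether the same exchange would read alike on the amide of compound 1, for which only a limit is available.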